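Amide-type nitrogen swap from compound 3 to compound 4

This account rests on a few compounds, and the source may have more. Where it says the series, first, only, none or still open, it means among the compounds named here.

Values in a functional assay on GBM1 cells (Homo sapiens) for antiproliferative activity, read by WST assay, with a stated time of 72 h; a lower number here means a stronger inhibitor, a higher number a weaker inhibitor:
- compound 1 `O=C(Nc1ccccc1F)Nc1cc2ncncc2cc1OCc1ccccc1`: 6100 nM
- compound 2 `O=C(Nc1cccc(Cl)c1)Nc1cc2ncncc2cc1OCc1cccc(Cl)c1`: 3300 nM
- compound 3 `O=C(Nc1ccc(C(F)(F)F)cc1)Nc1cc2ncncc2cc1OCc1ccccc1`: 5700 nM

Not yet measured: compound 4 `O=C(Nc1cccc(Cl)c1)Nc1cc2ncncc2cc1OCc1ccccc1`

In this assay compound 3 gives 5700 nM, which lies within the scatter of both other numbers, so the three measured compounds form a single group with no meaningful rank among them.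

The change under consideration is 3-chlorophenyl in place of 4-(trifluoromethyl)phenyl on an amide-type nitrogen.

One measured step changes the group at this place: a 1.1-fold lower number from compound 1 to compound 3 (0.03 log units; within the scatter). That step suggests little sensitivity to the group at this place, though it rests on a single pair. The 3-chlorophenyl group itself appears only in compound 2, at 3300 nM, which also differs from compound 4 elsewhere in its structure and so offers no clean comparison. Its number gives only a weak hint towards a lower value.

No change beyond the scatter is therefore expected in this assay. The expected size is a 1.3-fold lower number from compound 3 to compound 4 (0.10 log units; within the scatter), and the direction of this estimated step is not secure.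

For compound 4 the estimated value is 4500 nM, with an expected range from 2300 nM to 8800 nM.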

Compound 4, half-maximal inhibitory concentration: 5700 nM
Compound 4: the middle estimate sits 1.3-fold (0.10 log units) below what was measured; the measured number falls inside the stated range.
By their numbers in this assay, from the lowest: compounds 2, 3, 4 and 1 (each within the scatter of the next).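

In this assay, the 3-chlorophenyl group on the amide-type nitrogen gives no change at the digits printed from compound 3 to compound 4 (within the scatter) and, against 2-fluorophenyl, a 1.1-fold lower number from compound 1 to compound 4 (0.03 log units; within the scatter) with the rest of the structure unchanged. Together with the earlier step, this places three different substituted phenyl groups at this nitrogen within the scatter of one another, and the 3-chlorophenyl group now has clean comparisons at this place. Compound 2 also gains a partner differing in one place, since hydrogen in place of chloro on an aromatic carbon gives a 1.7-fold higher number from compound 2 to compound 4 (0.24 log units; within the scatter) and so this second chloro shows no change beyond the scatter. No measurement on hand accounts for this flat response.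

The compounds shown leave open whether any group on this nitrogen can move the number beyond the scatter, for example a phenyl ring carrying a carboxylic acid or an amine, or a cyclohexyl group in place of the aromatic ring. They also leave open how far the benzyl ether tolerates change, for example a longer chain between the oxygen and the phenyl ring.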